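Heteroaryl exchange on the shared core: outlook for compound 4

The compounds below may be only part of what the source reports. "The series", "measured", "known", "first", "only" and "open" are said of these compounds alone.

Compound 1 `CCCCCCCCc1ccc(OCC(=O)Cn2nnc(-c3ccccc3)n2)cc1` gives 24 nM in an assay on microsomes from brain for inhibition of Fatty-acid amide hydrolase 1 (Rattus norvegicus), read by fluorescence and HPLC, with a stated time of 60 min; a higher number here means a weaker inhibitor, a lower number a stronger inhibitor. In this assay compound 2 `CCCCCCCCc1ccc(OCC(=O)Cn2nnc(-c3ccc(C(=O)OC)cc3)n2)cc1` gives 29 nM and compound 3 `CCCCCCCCc1ccc(OCC(=O)Cn2nnc(-c3ccccn3)n2)cc1` gives 18 nM. All steps among them are small: a 1.2-fold higher number from compound 1 to compound 2 (0.08 log units; within the scatter), a 1.3-fold lower number from compound 1 to compound 3 (0.12 log units; within the scatter) and a 1.6-fold lower number from compound 2 to compound 3 (0.21 log units; within the scatter). Compound 3 therefore stands apart from neither compound 1 nor compound 2 on these numbers.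

Compound 4 `CCCCCCCCc1ccc(OCC(=O)Cn2nnc(-c3cccs3)n2)cc1` differs from compound 3 by thiophen-2-yl in place of pyridin-2-yl on an aromatic carbon. The three steps above are the ones that bear on it, each an exchange of the group at this same place, and each within the scatter. No step beyond the scatter is therefore expected for compound 4 in this assay, in either direction. Compound 4 is estimated at 22 nM, with a range from 10 nM to 50 nM. This estimate means an expected step of a 1.2-fold higher number from compound 3 to compound 4 (0.09 log units; within the scatter).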

Compound 4, half-maximal inhibitory concentration: 32 nM
Compound 4: the middle estimate sits 1.5-fold (0.16 log units) below what was measured, and the stated range covers the measured number.
By their numbers in this assay, from the lowest: compounds 3, 1, 2 and 4 (each within the scatter of the next).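

A five-membered aromatic ring with sulfur, thiophen-2-yl, now occupies this place on the shared core, and in this assay the steps remain small: a 1.8-fold higher number from compound 3 to compound 4 (0.25 log units; within the scatter) and a 1.1-fold higher number from compound 2 to compound 4 (0.04 log units; within the scatter) and a 1.3-fold higher number from compound 1 to compound 4 (0.12 log units; within the scatter) for the exchanges tested. Across these four compounds, neither ring size nor the hetero atom of the group separates the numbers, and no compound goes against this. Nothing available explains these small steps.

Open, from the compounds shown here alone, is whether this place also accepts a non-aromatic group, such as an amine or a carboxylic acid, without a step beyond the scatter.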